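Step from compound 1 to compound 4 on the carbonyl carbon

The source may hold more compounds than are shown below. What is called first, only, known or untested is meant among the compounds shown, and "the series" means these compounds.

Compound 1 `COc1cc(-c2nnc(SCC(=O)c3ccc(Cl)cc3)n2N)cc(OC)c1OC` is measured in a functional assay on HCT-116 cells (Homo sapiens) for antiproliferative activity, read by MTT assay, with a stated time of 48 h (a lower number here means a stronger inhibitor, a higher number a weaker inhibitor), at 7500 nM. Among the three numbers so far it stands second highest: compound 2 `COc1cc(-c2nnc(SCC(=O)c3ccc(F)c(F)c3)n2N)cc(OC)c1OC` gives 10400 nM, and a 1.4-fold higher number from compound 1 to compound 2 (0.14 log units; within the scatter); compound 3 `COc1cc(-c2nnc(SCC(=O)Nc3ccccc3)n2N)cc(OC)c1OC` gives 1730 nM, and a 4.3-fold lower number from compound 1 to compound 3 (0.64 log units; beyond the scatter). Compound 4 `COc1cccc(NC(=O)CSc2nnc(-c3cc(OC)c(OC)c(OC)c3)n2N)c1` differs from compound 1 in one place: (3-methoxyphenyl)amino in place of 4-chlorophenyl on a carbonyl carbon. For the measured compounds named here, two measured steps bear on this. Both a 4.3-fold lower number from compound 1 to compound 3 (0.64 log units; beyond the scatter) and a 6.0-fold lower number from compound 2 to compound 3 (0.78 log units; beyond the scatter) replace an aryl group on the carbonyl carbon with an anilino group, and both lower the number modestly, beyond the scatter. Going by the values given here, the change to compound 4 is the same exchange with a methoxy group added on the entering ring; no measured pair shows what that methoxy alone does, so the expectation rests on the anilino steps. A modest step towards a lower number is therefore expected, of about the size seen to compound 3. Compound 4 is expected at 1900 nM, range 700 nM to 5500 nM, which is expected to mean a 3.9-fold lower number from compound 1 to compound 4 (0.60 log units; beyond the scatter).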

Compound 4, half-maximal inhibitory concentration: 680 nM
Compound 4: the middle estimate sits 2.8-fold (0.45 log units) above what was measured; the whole stated range lies above it.
By their numbers in this assay, from the lowest: compound 4; then compound 3; then compounds 1 and 2 (each within the scatter of the next).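

For the compounds shown here, the single added methoxy group can now be read on its own: a 2.5-fold lower number from compound 3 to compound 4 (0.41 log units; beyond the scatter), a modest step beyond the scatter that the anilino exchange alone did not show. With this group on the entering ring, the full exchange on the carbonyl carbon grows from the modest steps seen to compound 3 to large ones, an 11-fold lower number from compound 1 to compound 4 (1.04 log units; beyond the scatter) and a 15-fold lower number from compound 2 to compound 4 (1.18 log units; beyond the scatter), so (3-methoxyphenyl)amino is the better of the two anilino groups shown here. No measurement bearing on the reason for these steps is available.

As far as these compounds go, whether an ethoxy group, a hydroxy group or a chlorine in place of the methoxy would give a step of similar size remains open. So does the effect of a methyl group in place of the amide hydrogen.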